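Shifting the chloro on the phenoxy arm

The compounds below may be only part of what the source reports. "The series", "measured", "known", "first", "only" and "open" are said of these compounds alone.

Compound 2 `O=C(O)c1csc([C@H]2CC[C@@H]3[C@@H](COc4cccc(Cl)c4)[C@H](O)C[C@@H]3O2)n1` stands second highest of the three numbers in a functional assay on CHO cells for agonist activity at prostaglandin E2 receptor EP2 subtype (Homo sapiens), read by HTRF and cAMP accumulation, with a stated time of 30 min (on this read-out higher numbers stand for an effect only at larger amounts of compound and lower numbers for an effect already at smaller amounts), giving 6.5 nM. For the measured compounds named here, compound 1 `O=C(O)c1csc([C@H]2CC[C@@H]3[C@@H](COc4ccc(OC(F)(F)F)cc4)[C@H](O)C[C@@H]3O2)n1` gives 14 nM, and compound 3 `O=C(O)c1csc([C@H]2CC[C@@H]3[C@@H](COc4cccc(OC(F)(F)F)c4)[C@H](O)C[C@@H]3O2)n1` gives 0.9 nM; the step of a 7.2-fold lower number from compound 2 to compound 3 (0.86 log units; beyond the scatter) is the only measured step in this set. Compound 4 `O=C(O)c1csc([C@H]2CC[C@@H]3[C@@H](COc4ccccc4Cl)[C@H](O)C[C@@H]3O2)n1` is not yet measured; it differs from compound 2 by 2-chlorophenyl in place of 3-chlorophenyl on an oxygen on a saturated carbon. Going by the values given here, no measured step moves a group from one position to another, so none bears directly on this change; compounds 1 and 3 carry the same group at different positions and show values far apart, which suggests that position matters here. Compound 4 is therefore expected to lose some potency, with an estimated step of a 2.3-fold higher number from compound 2 to compound 4 (0.36 log units; beyond the scatter). Compound 4 is estimated at 15 nM, within 4 nM to 60 nM.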

Compound 4, half-maximal effective concentration: 3.3 nM
Beside the measured number, compound 4's estimate is 4.5-fold (0.66 log units) above it; the measured number lies below the stated range.
By their numbers in this assay, from the lowest: compound 3; then compounds 4 and 2 (each within the scatter of the next); then compound 1.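

In this assay, for the compounds shown here, the change to 2-chlorophenyl gives a 2.0-fold lower number from compound 2 to compound 4 (0.29 log units; within the scatter) and is the first direct test of moving a group around this ring. For chloro, then, 3-chlorophenyl and 2-chlorophenyl cannot be told apart on this read-out, although compound 1 at 14 nM and compound 3 at 0.9 nM show that the place of trifluoromethoxy can go with very different numbers. No evidence is available to explain this result. The compounds shown leave open whether a methoxy group or a nitrile in place of the chloro would be as indifferent to this move.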